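A few compounds are considered here, and "the series" means these few. Any claim that something is new, unique, unknown or untested is made for them only; others in the source may bear on it.

Measured compounds:
- compound 1 `FC(F)(F)c1cccc(CNc2cc(C(F)(F)F)cc3[nH]ncc23)c1`: 49%
- compound 2 `FC(F)(F)c1cc(NCC2CNC2)c2cn[nH]c2c1`: 22%
- compound 3 `FC(F)(F)c1cc(NC[C@@H]2CCCCN2)c2cn[nH]c2c1`: 81%

In an assay for inhibition of Indoleamine 2,3-dioxygenase 1 (Homo sapiens), with stated times of 10 min and 60 min, tested at 100 uM (on this read-out higher numbers stand for a stronger effect at the one concentration tested and lower numbers for a weaker effect), compound 3 stands highest of the three, beyond the scatter above compound 1 and beyond the scatter above compound 2. Compound 4 `Nc1cccc(CNc2cc(C(F)(F)F)cc3[nH]ncc23)c1` is not yet measured. Its change from compound 3 is 3-aminophenyl in place of piperidin-2-yl on a saturated chain carbon bound to a nitrogen on an aromatic ring. Within the data shown here, the only step at this place is a number 59 percentage points higher from compound 2 to compound 3 (beyond the scatter), which shows that a change of the group on this saturated chain carbon can move the read-out strongly. Compound 1 carries an aromatic ring there and gives 49%, well below compound 3. An aromatic ring also enters in compound 4, so a drop toward the level of compound 1 is expected: a number 31 percentage points lower from compound 3 to compound 4 (beyond the scatter). Compound 4 is therefore estimated at 50%, with a range from 25% to 75%.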

Compound 4, a percentage reported as inhibition, at one concentration (the size of the read-out at that concentration, not a potency): 55%
Compound 4: the middle estimate sits 5 percentage points below what was measured; the range from low to high includes it.
By their numbers in this assay, from the lowest: compound 2; then compounds 1 and 4 (each within the scatter of the next); then compound 3.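

In this assay, 3-aminophenyl on the saturated chain carbon gives up part of the read-out of piperidin-2-yl (a number 26 percentage points lower from compound 3 to compound 4 (beyond the scatter)) but clearly outdoes azetidin-3-yl (a number 33 percentage points higher from compound 2 to compound 4 (beyond the scatter)), so the three groups on this carbon fall into a clear order. On the aromatic ring itself, amino in place of trifluoromethyl leaves the two compounds within the scatter (a number 6 percentage points higher from compound 1 to compound 4 (within the scatter)). No measurement on hand accounts for these differences. Still open, as far as these compounds go, is whether a carboxylic acid or nitrile on that aromatic ring would stand apart from amino and trifluoromethyl. From the compounds shown here alone, a pyrrolidin-2-yl ring or a longer chain on the saturated chain carbon also remains untested against piperidin-2-yl in these compounds.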